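This account rests on a few compounds, and the source may have more. Where it says the series, first, only, none or still open, it means among the compounds named here.

Measured compounds in an assay on membranes from HeLa cells for displacement of a labelled ligand from adenosine receptor A3 (Homo sapiens), read by scintillation counting, with a stated time of 180 min, tested at 1 uM; on this read-out lower numbers stand for less inhibition and higher numbers for more inhibition at the one concentration tested (going by the name of the read-out):
- compound 1 `CC1=C(C(=O)OC(C)(C)C)C(c2ccoc2)NC(=O)N1`: 2%
- compound 2 `CC1=C(C(=O)OCC2CC2)C(c2ccco2)NC(=O)N1`: 1%
- compound 3 `CC1=C(C(=O)OC2CCCC2)C(c2ccoc2)NC(=O)N1`: 1%

Compound 3 stands level with compound 2 at the digits shown, and the two together give the lowest numbers of the three. Compound 1 lies a single point higher, which is within the scatter, so the three measured values cannot be ordered against each other.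

The next compound in the series is compound 4 `CC1=C(C(=O)OCC2CC2)C(c2ccoc2)NC(=O)N1`. It differs from compound 3 only in the ester group: cyclopropylmethyl in place of cyclopentyl on an oxygen next to a carbonyl group.

One measured step speaks to this change, the exchange of the ester group in the same place between compound 1 and compound 3: a number 1 percentage points lower from compound 1 to compound 3 (within the scatter). Exchanging one ester alkyl for another therefore left this assay unmoved there. Compound 2 already carries the cyclopropylmethyl ester and gives 1%, the same figure as compound 3 at the digits shown, though its furan ring is joined differently, so no step between compound 2 and compound 3 or compound 4 is computed here.

For compound 4 no movement beyond the scatter is expected, so the estimated step is a number 1 percentage points higher from compound 3 to compound 4 (within the scatter). Compound 4 is estimated at 2%, with a range from -6% to 10%.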

Compound 4, a percentage reported as inhibition, at one concentration (the size of the read-out at that concentration, not a potency): 3%
Estimate against measurement, compound 4: 1 percentage points below; the measured number falls inside the stated range.
By their numbers in this assay, from the lowest: compounds 2, 3, 1 and 4 (each within the scatter of the next).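

In this assay the ester position now holds three alkyl groups on the furan-3-yl compounds, and the steps read a number 2 percentage points higher from compound 3 to compound 4 (within the scatter) and a number 1 percentage points higher from compound 1 to compound 4 (within the scatter), so cyclopropylmethyl, cyclopentyl and tert-butyl on an oxygen next to a carbonyl group are not told apart. For the compounds shown here, the furan attachment can also be read for the first time, as furan-3-yl in place of furan-2-yl on a saturated ring carbon gives a number 2 percentage points higher from compound 2 to compound 4 (within the scatter), and this second kind of change leaves the reading within the scatter as well. No measurement shown offers a reason for these readings.

As far as these compounds go, whether a carboxylic acid, an amine or a longer chain on that oxygen, or a phenyl ring in place of the furan, would shift this assay remains open. A single concentration also gives no potency for any of the four compounds.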